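This account rests on a few compounds, and the source may have more. Where it says the series, first, only, none or still open, it means among the compounds named here.

The compounds in this set share one core and were tested in an assay on isolated protein for inhibition of vitamin D3 receptor (Homo sapiens), read by fluorescence polarization; on this read-out higher numbers stand for weaker inhibition and lower numbers for stronger inhibition. Compound 1, with the structure `CN(CC(=O)N(Cc1ccccc1)Cc1ccccc1)C(=O)c1ccc(S(C)(=O)=O)c([N+](=O)[O-])c1`, is one of them. In this assay compound 1 gives only a limit, > 60000 nM. Compound 3, drawn as `CN(CC(=O)N1CCc2ccccc2C1)C(=O)c1ccc(S(C)(=O)=O)c([N+](=O)[O-])c1`, is a second member. In this assay compound 3 likewise gives only a limit, > 60000 nM. Compound 2, with the structure `CC(C)N(C(=O)CNC(=O)c1ccc(S(C)(=O)=O)c([N+](=O)[O-])c1)C(C)C`, carries a diisopropylamino group on the carbonyl carbon of its chain. In this assay compound 2 also gives only a limit, > 60000 nM. Compound 2 therefore cannot be ranked against the others: all three values sit at the limit of > 60000 nM in this assay, at which 3 of the 3 values shown sit, and none of them is a number.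

Compound 4, drawn as `CN1CCN(C(=O)CNC(=O)c2ccc(S(C)(=O)=O)c([N+](=O)[O-])c2)CC1`, is still to be measured. It differs from compound 2 in one place: 4-methylpiperazin-1-yl in place of diisopropylamino on a carbonyl carbon. Within the data shown here, no step between two measured compounds is known here, so the size of this change has nothing to rest on. Because all three measured values sit at the limit of > 60000 nM in this assay, at which 3 of the 3 values shown sit, the step from compound 2 to compound 4 is expected to be a step that the limit leaves unreadable from compound 2 to compound 4, that is, nothing beyond the scatter. Compound 4 is accordingly expected to give about 80000 nM, with a range from 20000 nM to 300000 nM, and most probably to be reported again only as a limit.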

Compound 4, half-maximal inhibitory concentration: > 60000 nM
Compound 4: no number, only a limit; the forecaster's own chance of this, stated with the estimate: 85%; the middle value does not contradict the limit.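

No step can be read between compound 2 and compound 4 in this assay, because both give only a limit and no number: the limit of > 60000 nM in this assay, at which 4 of the 4 values shown sit.

The compounds shown leave open whether diisopropylamino and 4-methylpiperazin-1-yl differ at all in this binding test, and which change to the shared core, if any, would give a measurable value.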